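The source may hold more compounds than are shown below. What is called first, only, known or untested is meant among the compounds shown, and "the series" means these compounds.

Compound 1 `CN1CCN(c2ccc(Nc3ncc4nc(Nc5ccccc5)n([C@@H]5CCNC5)c4n3)cc2)CC1` and compound 2 `CN1CCN(c2ccc(Nc3ncc4nc(Nc5ccc(F)cc5)n(CCNS(=O)(=O)C5CC5)c4n3)cc2)CC1` share one core and differ at two places. In a functional assay on HCC827 cells (Homo sapiens) for antiproliferative activity, read by MTT assay, with a stated time of 72 h (a higher number here means a weaker inhibitor, a lower number a stronger inhibitor), compound 1 gives 65 nM, and compound 2 gives 50 nM; the two numbers lie within the usual scatter of each other, so on what has been measured compound 2 cannot be told apart from compound 1, and neither compound can be called the more potent.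

Compound 3 `CN1CCN(c2ccc(Nc3ncc4nc(Nc5ccc(F)cc5)n([C@H]5CCN(C(=O)CO)C5)c4n3)cc2)CC1` is the next compound to be measured. It differs from compound 2 by 1-((hydroxymethyl)carbonyl)pyrrolidin-3-yl in place of 2-((cyclopropylsulfonyl)amino)ethyl on an aromatic nitrogen. Among the measured compounds shown here, no measured pair shows the effect of this exchange on its own, so the expectation rests on the fact that both measured compounds sit close together. The step is expected to be small, no change at the digits printed from compound 2 to compound 3 (within the scatter), with no clear direction beyond the scatter. Compound 3 is therefore estimated to give 50 nM in this assay, within a range from 15 nM to 170 nM.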

Compound 3, half-maximal inhibitory concentration: 380 nM
Compound 3: the middle estimate sits 7.6-fold (0.88 log units) below what was measured, and the stated range ends below it.
By their numbers in this assay, from the lowest: compounds 2 and 1 (each within the scatter of the next); then compound 3.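

Replacing 2-((cyclopropylsulfonyl)amino)ethyl with 1-((hydroxymethyl)carbonyl)pyrrolidin-3-yl on the aromatic nitrogen gives a 7.6-fold higher number from compound 2 to compound 3 (0.88 log units; beyond the scatter) in this assay and shows that the number responds to what sits at this position. The two groups have the same counts of heavy atoms, hydrogen-bond donors and hydrogen-bond acceptors, and neither carries a net charge, so these counts alone do not settle how a group fares here. No measurement among these compounds accounts for the step.

This single exchange alters the ring, the sulfonyl group and the carbonyl group together, so the part that matters cannot be singled out. An acetyl group on the pyrrolidine nitrogen, or a 2-(acetylamino)ethyl chain, would help to separate these parts.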